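Dropping the Phenyl Ring: Cytotoxicity Still Expected at the Limit

The compounds below may be only part of what the source reports. "The series", "measured", "known", "first", "only" and "open" are said of these compounds alone.

Of the compounds shown here, two have been tested in an ADME assay on HEK293 cells (Homo sapiens) for cytotoxicity, read by WST assay, with a stated time of 48 h; a lower number here means a stronger inhibitor, a higher number a weaker inhibitor. Compound 1 `CC(C)CC(=O)[C@@H]1O[C@@]12C(=O)C=C(Cc1ccccc1)NC2=O` gives only a limit of the assay, > 50000 nM. Compound 2 `CC(C)C[C@]1(O)NC(=O)[C@]2(OC(Cc3ccccc3)=CC2=O)[C@H]1O` likewise gives only a limit of the assay, > 50000 nM. Both measured values therefore sit at the same limit, (the limit of > 50000 nM in this assay, at which 2 of the 2 values shown sit), and nothing can be said about any difference between compound 1 and compound 2.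

Compound 3 `CC1=CC(=O)[C@]2(O1)C(=O)N[C@@](O)(CC(C)C)[C@@H]2O` has not been measured. It differs from compound 2 in one place: hydrogen in place of phenyl on a saturated chain carbon bound to a double-bonded ring carbon. Going by the values given here, no step between measured compounds is available to guide this change, and the two measured values share one limit. The expectation is that no step beyond the usual scatter appears. In this assay the expected step is a step that the limit leaves unreadable from compound 2 to compound 3. Compound 3 is thus estimated at 80000 nM, within a range from 30000 nM to 300000 nM, most likely reported again as a limit.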

Compound 3, half-maximal inhibitory concentration: > 50000 nM
Compound 3 was reported as a limit; the forecaster's own chance of this, stated with the estimate: 90%; the middle value does not contradict the limit.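

Compound 2 and compound 3 are both reported only as limits, so no step between them can be read in this assay: the limit of > 50000 nM in this assay, at which 3 of the 3 values shown sit.

The compounds shown leave open whether hydrogen in place of phenyl changes cytotoxicity at all, and whether any of these compounds has a measurable effect on these cells.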